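Swapping one ether group on a high-scoring compound

A few compounds are considered here, and "the series" means these few. Any claim that something is new, unique, unknown or untested is made for them only; others in the source may bear on it.

In an ADME assay on microsomes from liver (Homo sapiens) for metabolic stability, with a stated time of 10 min (on this read-out higher numbers stand for a more stable compound and lower numbers for a less stable compound), three compounds have numbers so far:
Compound 1 `O=C(N1CCOCC1)N1CC[C@](c2ccc(C(OCc3c(F)cccc3F)(C(F)(F)F)C(F)(F)F)cc2)(S(=O)(=O)c2ccc(F)cc2)C1` gives 3%
Compound 2 `O=C(O)C1CCN(C(=O)N2CC[C@](c3ccc(C(OCc4c(F)cccc4F)(C(F)(F)F)C(F)(F)F)cc3)(S(=O)(=O)c3ccc(F)cc3)C2)CC1` gives 72%
Compound 3 `O=C(O)[C@H]1CC[C@H](C(=O)N2CC[C@](c3ccc(C(OCc4ccccc4OC(F)(F)F)(C(F)(F)F)C(F)(F)F)cc3)(S(=O)(=O)c3ccc(F)cc3)C2)CC1` gives 93%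

Compound 3 holds the highest of these three numbers, beyond the scatter of repeat measurements against both compound 2 and compound 1. The next compound is compound 4 (`O=C(O)[C@H]1CC[C@H](C(=O)N2CC[C@](c3ccc(C(OCC4CC4)(C(F)(F)F)C(F)(F)F)cc3)(S(=O)(=O)c3ccc(F)cc3)C2)CC1`), and the change is cyclopropyl in place of 2-(trifluoromethoxy)phenyl on a saturated chain carbon bound to an oxygen on a saturated carbon on a saturated chain carbon bound to an oxygen on a saturated carbon. Cut one bond further out, 2-(trifluoromethoxy)benzyl becomes cyclopropylmethyl.

Going by the values given here, only one measured step exists, a number 69 percentage points higher from compound 1 to compound 2 (beyond the scatter) and it is large. It brought in 4-carboxypiperidin-1-yl on a carbonyl carbon, which is a different place from the one changing now. Among the compounds with values here, no measured pair isolates the ether group, so the evidence here is indirect. Compound 4 keeps the carboxy-bearing side of compound 3, at 93% on the read-out, and so a large fall is not expected. The estimated change is a number 5 percentage points lower from compound 3 to compound 4 (within the scatter) and it is expected to stay within the scatter. For compound 4 the estimate is 88% as the middle, with an expected range from 70% to 100% around it.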

Compound 4, percent of the compound remaining: 75%
For compound 4 the middle estimate is 13 percentage points above the measured one; low and high end bracket the measured number.
By their numbers in this assay, from the lowest: compound 1; then compounds 2 and 4 (each within the scatter of the next); then compound 3.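

Going by these compounds alone, the change on the saturated chain carbon bound to an oxygen on a saturated carbon is the first measured step at this place, and it shows that the read-out responds here even with the carboxy-bearing side kept: in this assay the step is a number 18 percentage points lower from compound 3 to compound 4 (beyond the scatter). The step is still smaller than a number 69 percentage points higher from compound 1 to compound 2 (beyond the scatter), so exchanging 2-(trifluoromethoxy)phenyl, with 11 heavy atoms, for cyclopropyl, with 3, costs some of the stability without taking most of it away, and compound 4 still gives 75%. No measurement on hand explains why the number fell.

This single step changes several things at once, as an aromatic ring, an oxygen and three fluorines leave together, so the compounds shown cannot say which of these matters. Also open, on these data alone, is where a plain phenyl, with no trifluoromethoxy group, or a longer chain such as n-butyl would fall at this place relative to compound 3 and compound 4, and whether an amine on that chain would change the picture.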